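From phenyl to pyridin-4-yl on an oxygen

The compounds below may be only part of what the source reports. "The series", "measured", "known", "first", "only" and "open" are said of these compounds alone.

In an ADME assay on HeLa cells (Homo sapiens) for cytotoxicity, read by MTT assay, with a stated time of 2 days (a lower number here means that less compound is tolerated, a higher number that more compound is tolerated), compound 2 `CCOC(=O)c1cc2ccc(Oc3ccccc3)cc2s1` gives 90100 nM. For the measured compounds named here, compound 3 `CCOC(=O)c1sc2cc(Oc3ccccc3)ccc2c1C` gives 47600 nM, and this pair, a 1.9-fold lower number from compound 2 to compound 3 (0.28 log units; within the scatter), is the only measured step, with methyl in place of hydrogen on an aromatic carbon. Compound 1 `CCOC(=O)c1cc2ccc(Oc3ccnc(C(=O)NC)c3)cc2s1` gives > 100000 nM, which is a limit of the assay and not a number.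

Compound 4 `CCOC(=O)c1cc2ccc(Oc3ccncc3)cc2s1` differs from compound 2 by pyridin-4-yl in place of phenyl on an oxygen on an aromatic ring. Going by the values given here, no measured step makes this change, so no step beyond the scatter is expected in either direction. Compound 4 could also be expected to reach (the limit of > 100000 nM in this assay, at which 1 of the 3 values shown sits). The expected change is a 1.1-fold lower number from compound 2 to compound 4 (0.03 log units; within the scatter). Compound 4 is estimated at 85000 nM, within a range of 42000 nM to 150000 nM.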

Compound 4, half-maximal cytotoxic concentration: 43900 nM
Compound 4: middle estimate off by 1.9-fold (0.29 log units), on the high side; measured number inside the range.
By their numbers in this assay, from the lowest: compounds 4, 3 and 2 (each within the scatter of the next, the first and the last beyond it). At a limit, above all of these: compound 1.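

In this assay, the group on the oxygen makes a readable difference: pyridin-4-yl in place of phenyl gives a 2.1-fold lower number from compound 2 to compound 4 (0.31 log units; beyond the scatter), whereas the methyl step lay within the scatter. Hydrogen in place of methylcarbamoyl on an aromatic carbon gives an at least 2.2-fold lower number from compound 1 to compound 4 (0.35 log units; beyond the scatter), so the pyridin-4-yl ring is tolerated less without that group. Compound 1 stands at a limit of the assay, not at a number: the limit of > 100000 nM in this assay, at which 1 of the 4 values shown sits.

From the compounds shown here alone, it remains open whether an amine or a carboxylic acid on that aromatic carbon would act like methylcarbamoyl. Going by these compounds, the pyridin-4-yl change also remains untested alongside the methyl of compound 3.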